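The compounds below may be only part of what the source reports. "The series", "measured", "known", "first", "only" and "open" are said of these compounds alone.

Compound 1 `CCN1CCN(C[C@H]2CN(c3ccc(-n4cc(-c5ccccn5)cn4)c(F)c3)C(=O)O2)CC1` gives 706000 nM in a physicochemical assay for solubility, read by HPLC, with a stated time of 24 h; a lower number here means a less soluble compound, a higher number a more soluble compound. Compound 2 `CCC(=O)NC[C@H]1CN(c2ccc(-n3cc(-c4ccccn4)cn3)c(F)c2)C(=O)O1` gives 147000 nM in this assay. Compound 3 `CS(=O)(=O)NC[C@H]1CN(c2ccc(-n3cc(-c4ccccn4)cn3)c(F)c2)C(=O)O1` gives 2300 nM in this assay.

Compound 3 stands lowest of the three measured numbers: against compound 1 the step is a 310-fold lower number from compound 1 to compound 3 (2.49 log units; beyond the scatter), and against compound 2 it is a 64-fold lower number from compound 2 to compound 3 (1.81 log units; beyond the scatter). Compound 4 `O=C(NC[C@H]1CN(c2ccc(-n3cc(-c4ccccn4)cn3)c(F)c2)C(=O)O1)C(F)F` differs from compound 3 by (difluoromethyl)carbonyl in place of methylsulfonyl on an amine nitrogen. The measured step that bears on this change is a 64-fold lower number from compound 2 to compound 3 (1.81 log units; beyond the scatter), in which a methylsulfonyl replaced a propanoyl on the same amine nitrogen. Compound 4 returns a carbonyl to that nitrogen, though not the propanoyl of compound 2. Compound 4 is therefore expected to move back upward by about a 17-fold higher number from compound 3 to compound 4 (1.24 log units; beyond the scatter), landing at an estimated 40000 nM, within a range from 8000 nM to 150000 nM.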

Compound 4, solubility: 29900 nM
Estimate against measurement, compound 4: 1.3-fold (0.13 log units) above; measured number inside the range.
By their numbers in this assay, from the lowest: compound 3; then compound 4; then compound 2; then compound 1.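

On the amine nitrogen, (difluoromethyl)carbonyl in place of methylsulfonyl gives a 13-fold higher number from compound 3 to compound 4 (1.11 log units; beyond the scatter) in this assay and so shows that a carbonyl other than propanoyl also stands above the sulfonyl there. The group on the carbonyl carbon still counts, with difluoromethyl in place of ethyl giving a 4.9-fold lower number from compound 2 to compound 4 (0.69 log units; beyond the scatter) and the swap from 4-ethylpiperazin-1-yl to ((difluoromethyl)carbonyl)amino giving a 24-fold lower number from compound 1 to compound 4 (1.37 log units; beyond the scatter) as a gap that remains. Nothing measured here accounts for these steps. Open, from the compounds shown here alone, is how an acetyl, a trifluoroacetyl or a longer acyl chain on that nitrogen would read, and whether a smaller amine such as morpholine would match 4-ethylpiperazin-1-yl on the saturated chain carbon.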